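The compounds below may be only part of what the source reports. "The series", "measured", "known", "first", "only" and "open" are said of these compounds alone.

Compound 1 `COc1ncc(-c2ccc3c(c2)N(c2ccccc2)C(=O)CO3)cc1NS(=O)(=O)c1ccc(F)cc1` and compound 3 `O=C1COc2ccc(-c3cnc(Cl)c(NS(=O)(=O)c4ccc(F)cc4)c3)cc2N1c1ccccc1` share a core that differs in one place: chloro in place of methoxy on an aromatic carbon. In a functional assay on A549 cells (Homo sapiens) for antiproliferative activity, read by MTT assay, with a stated time of 72 h (a higher number here means a weaker inhibitor, a lower number a stronger inhibitor), compound 1 gives 3490 nM, and compound 3 gives 14700 nM, a step of a 4.2-fold higher number from compound 1 to compound 3 (0.62 log units; beyond the scatter). Compound 2 `COc1ncc(-c2ccc3c(c2)N(C2CC2)C(=O)CO3)cc1NS(=O)(=O)c1ccc(F)cc1` comes from compound 1 by a change seen twice among these compounds: cyclopropyl in place of phenyl on an amide-type nitrogen in a ring. Compound 2 gives 3320 nM in this assay, so the step is a 1.1-fold lower number from compound 1 to compound 2 (0.02 log units; within the scatter). Compound 4 `O=C1COc2ccc(-c3cnc(Cl)c(NS(=O)(=O)c4ccc(F)cc4)c3)cc2N1C1CC1` is not yet measured and comes from compound 3 by the same change, at the same place: cyclopropyl in place of phenyl on an amide-type nitrogen in a ring. For compound 4 the expected step is a 1.1-fold lower number from compound 3 to compound 4 (0.02 log units; within the scatter), resting on compound 2, where the same change gave a 1.1-fold lower number from compound 1 to compound 2 (0.02 log units; within the scatter). Compound 4 is therefore estimated at 14000 nM in this assay, expected between 7000 nM and 28000 nM.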

Compound 4, half-maximal inhibitory concentration: 4330 nM
Estimate against measurement, compound 4: 3.2-fold (0.51 log units) above; measured number outside the range, below it.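

In this assay, cyclopropyl in place of phenyl gives a 3.4-fold lower number from compound 3 to compound 4 (0.53 log units; beyond the scatter), yet this size of step did not carry over from the core bearing methoxy: the same change on two cores in this assay, a 1.1-fold lower number (0.02 log units; within the scatter) from compound 1 to compound 2 and a 3.4-fold lower number (0.53 log units; beyond the scatter) from compound 3 to compound 4, 3.2-fold (0.51 log units) apart, beyond the scatter of two such steps. Chloro in place of methoxy gives a 1.3-fold higher number from compound 2 to compound 4 (0.12 log units; within the scatter), so its size also depends on which group sits on the amide-type nitrogen: the same change on two cores in this assay, a 4.2-fold higher number (0.62 log units; beyond the scatter) from compound 1 to compound 3 and a 1.3-fold higher number (0.12 log units; within the scatter) from compound 2 to compound 4, 3.2-fold (0.51 log units) apart, beyond the scatter of two such steps. These four compounds show that the two changes do not simply add up here, but they do not show why, or whether this holds on any other core.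

As far as these compounds go, it remains open how a small chain such as ethyl or a longer chain would behave on that nitrogen. From the compounds shown here alone, it also remains open whether an amine in place of chloro or methoxy would show the same dependence.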